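From 2-methoxyphenyl to 4-(trifluoromethyl)phenyl on an amine nitrogen

This account rests on a few compounds, and the source may have more. Where it says the series, first, only, none or still open, it means among the compounds named here.

In a functional assay on ECa-109 cells for inhibition, with ECa-109 cell line (Homo sapiens) as the target, read by sulforhodamine B assay (a higher number here means a weaker inhibitor, a lower number a stronger inhibitor), compound 2 (`COc1ccccc1NC1=CC(=O)c2nc3n(c2C1=O)[C@H]1OC[C@@H](O)[C@H]1OC3`) gives > 4000 nM as a limit of the assay, not a number. Compound 1 (`O=C1C=C(NC2CCCC2)C(=O)c2c1nc1n2[C@H]2OC[C@@H](O)[C@H]2OC1`) gives > 16000 nM which is likewise a limit. For the measured compounds named here, the one measured step, a step that the two limits leave unreadable from compound 1 to compound 2, has no readable size and offers no guide. Compound 3 (`O=C1C=C(Nc2ccc(C(F)(F)F)cc2)C(=O)c2c1nc1n2[C@H]2OC[C@@H](O)[C@H]2OC1`) has 4-(trifluoromethyl)phenyl in place of 2-methoxyphenyl on an amine nitrogen. Going by the values given here, no measured step bears on this change with a usable size, so no shift beyond the scatter is expected. The expected step is a step that the limit leaves unreadable from compound 2 to compound 3 with no firm direction. Compound 3 is estimated at 6000 nM within a range of 1500 nM to 20000 nM and may also return only a limit.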

Compound 3, half-maximal inhibitory concentration: 5500 nM
Beside the measured number, compound 3's estimate is 1.1-fold (0.04 log units) above it; measured number inside the range.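

In this assay, compound 3 is the only one of the three with a number rather than a limit, so 4-(trifluoromethyl)phenyl on an amine nitrogen brings a readable value to this series. Against cyclopentyl at this place, the change gives an at least 2.9-fold lower number from compound 1 to compound 3 (0.46 log units; beyond the scatter). The step from 2-methoxyphenyl cannot be read because compound 2 stands only at a limit: the limit of > 4000 nM in this assay, at which 1 of the 3 values shown sits.

From the compounds shown here alone, it remains open whether the step belongs to the aromatic ring itself or to the trifluoromethyl group. An unsubstituted phenyl on the same nitrogen would separate the two.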